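Moving the chlorine around a phenylamide and liver-cell tolerance

The compounds below may be only part of what the source reports. "The series", "measured", "known", "first", "only" and "open" are said of these compounds alone.

Compound 1 `O=C(CCSc1nnc(-c2ccncc2)s1)Nc1ccc(Cl)cc1` gives 7260 nM in an ADME assay on HepG2 cells (Homo sapiens) for cytotoxicity, with a stated time of 3 days; a higher number here means that more compound is tolerated, a lower number that less compound is tolerated.
Compound 2 `CC(CSc1nnc(-c2ccncc2)s1)C(=O)Nc1ccc(Cl)cc1Cl` gives > 50000 nM, which is a limit of the assay and not a number.
Compound 3 `CC(CSc1nnc(-c2ccncc2)s1)C(=O)Nc1ccccc1Cl` gives > 50000 nM, also only a limit.

Compound 3 therefore stands at the top of what this assay reports, and the step from compound 2 to compound 3 a step that the two limits leave unreadable from compound 2 to compound 3 cannot be sized because of the limit of > 50000 nM in this assay, at which 2 of the 3 values shown sit. Compound 4 `CC(CSc1nnc(-c2ccncc2)s1)C(=O)Nc1ccc(Cl)cc1` differs from compound 3 in one place: 4-chlorophenyl in place of 2-chlorophenyl on an amide-type nitrogen. Within the data shown here, no measured step covers this change. Compound 1 shares the 4-chlorophenyl group but differs elsewhere, and compound 3 is a limit, so the size of the step is open. The step to compound 4 is expected to be an at least 1.6-fold lower number from compound 3 to compound 4 (0.22 log units; that floor lies within the scatter), a modest move toward lower tolerance. Compound 4 is thus estimated at 30000 nM, between 8000 nM and 100000 nM.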

Compound 4, half-maximal cytotoxic concentration: > 50000 nM
Compound 4 gave a limit, no number; the forecaster's own chance of this, stated with the estimate: 45%; middle value at least 1.6-fold (0.22 log units) away from the limit.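

With the 4-chlorophenyl group held fixed, methyl in place of hydrogen on the saturated chain carbon bound to a carbonyl carbon and a saturated chain carbon gives an at least 6.8-fold higher number from compound 1 to compound 4 (0.83 log units; beyond the scatter) in this assay. The lower number of compound 1 therefore does not follow from the 4-chlorophenyl group alone. The steps linking compound 2, compound 3 and compound 4 cannot be read: the limit of > 50000 nM in this assay, at which 3 of the 4 values shown sit.

Going by these compounds, whether 2-chlorophenyl and 4-chlorophenyl differ at all remains open. Also open, on these data alone, is how a longer chain or an amine in place of the methyl would fare.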